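Benzyl Replaces Phenyl on a Tocotrienol Carbamate

The source may hold more compounds than are shown below. What is called first, only, known or untested is meant among the compounds shown, and "the series" means these compounds.

Compound 1: `CC(C)=CCC/C(C)=C/CC/C(C)=C/CC[C@]1(C)CCc2c(C)c(OC(=O)NS(=O)(=O)c3ccc(C)cc3)c(C)c(C)c2O1` — > 10000 nM in a functional assay on MDA-MB-231 cells (Homo sapiens) for antiproliferative activity, read by MTT assay, with a stated time of 96 h; on this read-out lower numbers stand for stronger inhibition and higher numbers for weaker inhibition (a limit, not a number).
Compound 2: `CC(C)=CCC/C(C)=C/CC/C(C)=C/CC[C@]1(C)CCc2cc(OC(=O)Nc3ccccc3)c(C)c(C)c2O1` — > 10000 nM in this assay (a limit, not a number).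
Compound 3: `Cc1c(C)c2c(c(C)c1OC(=O)[C@@H](N)CCCCN)CC[C@@](C)(CCCC(C)CCCC(C)CCCC(C)C)O2` — "not determined" (no result reported) in this assay (no result reported).

Compound 2 stands at the limit of > 10000 nM in this assay, at which 2 of the 3 values shown sit, and so has no measured number of its own, and the same holds for compound 1. Compound 3 gives no result at all. Within the data shown here, with no step between measured compounds available, nothing tells how a change on the amide-type nitrogen shifts potency here.

Compound 4, `CC(C)=CCC/C(C)=C/CC/C(C)=C/CC[C@]1(C)CCc2cc(OC(=O)NCc3ccccc3)c(C)c(C)c2O1`, differs from compound 2 in one place: benzyl in place of phenyl on an amide-type nitrogen. No change beyond the scatter is expected for a step that the limit leaves unreadable from compound 2 to compound 4. Compound 4 is therefore estimated near the limit at 12000 nM, within 4000 nM to 40000 nM.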

Compound 4, half-maximal inhibitory concentration: > 10000 nM
Compound 4: only a limit was reported; the forecaster's own chance of this, stated with the estimate: 70%; the middle value lies beyond the limit too.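

Among these compounds, compound 2 and compound 4 each give only a limit, not a number, and no step between them can be read. The compounds shown leave open whether benzyl or phenyl on the amide-type nitrogen changes potency in this assay at all.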